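Swapping the Pyridyl Arm on a Ketone Oxazole Inhibitor

The compounds below may be only part of what the source reports. "The series", "measured", "known", "first", "only" and "open" are said of these compounds alone.

Measured so far:
compound 1, `O=C(CCc1ccc(-c2ccccc2)cc1)c1ncc(-c2ccncc2)o1` — 2.3 nM
compound 2, `COC(=O)c1cccc(-c2cnc(C(=O)CCc3ccc(-c4ccc(CN5CCCC5)cc4)cc3)o2)n1` — 18 nM

In an assay for inhibition of Fatty-acid amide hydrolase 1 (Rattus norvegicus) (a lower number here means a stronger inhibitor, a higher number a weaker inhibitor), compound 1 gives 2.3 nM, the lowest of the two numbers. Among the measured compounds shown here, compound 2 gives a higher number, 18 nM, and it differs from compound 1 in more than one place, so no single step links them. Compound 3, `NC(=O)c1cccc(-c2cnc(C(=O)CCc3ccc(-c4ccccc4)cc3)o2)n1`, differs from compound 1 in one place: 6-carbamoylpyridin-2-yl in place of pyridin-4-yl on an aromatic carbon. For the measured compounds named here, no measured pair isolates this change, so for compound 3 the expected step is a 1.3-fold higher number from compound 1 to compound 3 (0.12 log units; within the scatter), not beyond the usual scatter. Compound 3 is estimated at 3 nM, with a range from 0.7 nM to 12 nM.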

Compound 3, inhibition constant: 1.2 nM
Beside the measured number, compound 3's estimate is 2.5-fold (0.40 log units) above it, within the range that was stated.
By their numbers in this assay, from the lowest: compounds 3 and 1 (each within the scatter of the next); then compound 2.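

Putting 6-carbamoylpyridin-2-yl in place of pyridin-4-yl gives a 1.9-fold lower number from compound 1 to compound 3 (0.28 log units; within the scatter) in this assay so the two compounds read alike. This position next to the ring oxygen therefore accepts a larger arm carrying a hydrogen-bond donor with no loss of inhibition beyond the scatter. No measurement here explains why the two arms read alike. Still open, from the compounds shown here alone, is whether a carboxylic acid or an amine in place of the carbamoyl group would also read alike. A single step also cannot show how far this tolerance extends.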